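Compound 3 and a longer sulfur side chain

The source may hold more compounds than are shown below. What is called first, only, known or untested is meant among the compounds shown, and "the series" means these compounds.

In a functional assay on the whole organism with Rattus norvegicus as the target (a higher number here means that more compound is needed for the effect, a lower number that less compound is needed), compound 1 (`N=c1sc2cc(OC(F)(F)F)ccc2n1Cc1ccccc1`) gives > 10 mg/kg as a limit of the assay, not a number. For the measured compounds named here, compound 2 (`C[S+]([O-])Cn1c(=N)sc2cc(OC(F)(F)F)ccc21`) gives 2.3 mg/kg and holds the only true number so far. Compound 3 (`CCCSCCn1c(=N)sc2cc(OC(F)(F)F)ccc21`) differs from compound 2 on a saturated chain carbon bound to an aromatic nitrogen, where (propylsulfanyl)methyl enters (a group of 5 heavy atoms (4 carbon, 1 sulfur; no ring) in place of a group of 3 heavy atoms (1 carbon, 1 oxygen, 1 sulfur; no ring), on a saturated chain carbon bound to an aromatic nitrogen). Going by the values given here, the one measured step at that place is an at least 4.3-fold lower number from compound 1 to compound 2 (0.63 log units; beyond the scatter) and it removed a six-membered aromatic ring. The entering group also has no ring, so only a small change is expected (a 1.3-fold higher number from compound 2 to compound 3 (0.12 log units; within the scatter)). In this assay the estimated value for compound 3 is 3 mg/kg with an expected range (1 mg/kg to 10 mg/kg).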

Compound 3, dose for half-maximal effect: 2.4 mg/kg
For compound 3 the middle estimate is 1.3-fold (0.10 log units) above the measured one, within the range that was stated.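

In this assay, two ring-free groups on a saturated chain carbon bound to an aromatic nitrogen now cannot be told apart, with a 1.0-fold higher number from compound 2 to compound 3 (0.02 log units; within the scatter). Putting (propylsulfanyl)methyl in place of phenyl gives an at least 4.1-fold lower number from compound 1 to compound 3 (0.61 log units; beyond the scatter), so a second ring-free group, larger than the first, also stands apart from phenyl. That step rests on a limit of the assay, not a number: the limit of > 10 mg/kg in this assay, at which 1 of the 3 values shown sits.

From the compounds shown here alone, whether a plain alkyl chain without sulfur would match these values remains open. So does the effect of a longer chain, an amine or a carboxylic acid at this place.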